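Hydroxy for amino at the cytotoxicity limit

The source may report more compounds than this note shows. Statements on the series, on what has been measured and on what is new or still open speak of the compounds shown alone.

Measured in a functional assay on CCRF-CEM cells (Homo sapiens) for cytotoxicity; a higher number here means a weaker inhibitor, a lower number a stronger inhibitor:
compound 1 `Nc1ncnc2c1ncn2[C@@H]1CC(F)(F)[C@H](CO)O1`: > 100000 nM
compound 2 `Nc1ncnc2c1ncn2[C@H]1CC(F)(F)[C@H](CO)O1`: > 100000 nM

Compound 1 stands only at a limit of this assay, > 100000 nM, and so gives no number. Compound 2 is likewise reported only as a limit, > 100000 nM. Among the compounds with values here, the one measured step is a step that the two limits leave unreadable from compound 1 to compound 2, and it concerns (the fact that compounds 1 and 2 differ only in the configuration as drawn). Compound 3 `OC[C@@H]1O[C@H](n2cnc3c(O)ncnc32)CC1(F)F` carries hydroxy in place of amino on an aromatic carbon. Within the data shown here, no measured step covers this change, so no step beyond the scatter is expected, in either direction. The expected step is a number no higher from compound 1 to compound 3 (the limit leaves the size open). Compound 3 is estimated at 100000 nM, with an expected range of 50000 nM to 200000 nM.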

Compound 3, half-maximal inhibitory concentration: > 100000 nM
Compound 3 gave a limit, no number (the forecaster's own chance of this, stated with the estimate: 90%); the middle value sits exactly at the limit.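

Within the data shown here, compound 3 gives only a limit (> 100000 nM), as compound 1 does, so no step from compound 1 to compound 3 can be read. The compounds shown leave open whether hydroxy in place of amino on an aromatic carbon changes potency at all.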